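The compounds below may be only part of what the source reports. "The series", "measured", "known", "first", "only" and "open" are said of these compounds alone.

Measured compounds:
Compound 1, `O=C1N=C(C2C(=O)c3ccccc3C2=O)CC(c2ccccc2[N+](=O)[O-])N1`, gives 30% in a functional assay on the whole organism for inhibition, with Rattus norvegicus as the target, read by paw edema, with stated times of 30 min and 2 h, at a dose of 10 mg/kg by the oral route; a lower number here means less inhibition, a higher number more inhibition at the dose given (going by the name of the read-out).
Compound 2, `COc1ccc(C2CC(C3C(=O)c4ccccc4C3=O)=NC(=O)N2)cc1`, gives 21%.
Compound 3, `O=C1N=C(C2C(=O)c3ccccc3C2=O)CC(/C=C/c2ccccc2)N1`, gives 32%.

Compound 3 has the highest of the three numbers, though its edge over compound 1 is within the scatter, as shown by a number 2 percentage points higher from compound 1 to compound 3 (within the scatter). Its gap to compound 2 is larger: a number 11 percentage points higher from compound 2 to compound 3 (beyond the scatter), a modest step beyond the scatter. The next compound is compound 4, `CN(C)c1ccc(C2CC(C3C(=O)c4ccccc4C3=O)=NC(=O)N2)cc1`, which has not been measured. It differs from compound 3 in one place: 4-(dimethylamino)phenyl in place of 2-phenylethenyl on a saturated ring carbon. Among the compounds with values here, the group that enters is an aromatic ring carrying a substituent, which resembles what compound 2 carries, so the step that bears most on this change is the one from compound 2 to compound 3, read in reverse. On that basis a modest decrease is expected, a number 10 percentage points lower from compound 3 to compound 4 (within the scatter), landing compound 4 near compound 2. The estimate for compound 4 is 22%, with a range from 10% to 34%.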

Compound 4, a percentage reported as inhibition, in the whole organism at one dose (the size of the read-out at that dose, not a potency): 29%
The estimate for compound 4 lay 7 percentage points below the measured number; measured number inside the range.
By their numbers in this assay, from the lowest: compounds 2, 4, 1 and 3 (each within the scatter of the next, the first and the last beyond it).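

In this assay, the result shows that 4-(dimethylamino)phenyl on this saturated ring carbon cannot be told apart from the two other groups there, with a number 3 percentage points lower from compound 3 to compound 4 (within the scatter) and a number 1 percentage points lower from compound 1 to compound 4 (within the scatter) as the two steps. Changing only the group on the aromatic ring, dimethylamino in place of methoxy, gives a number 8 percentage points higher from compound 2 to compound 4 (within the scatter) and so places compound 4 within the scatter of compound 2 and of compound 3, although those two lie beyond the scatter of each other. Nothing measured here offers an explanation for these numbers.

On these data alone, it remains open what a plain amino group or a carboxylic acid would give in place of dimethylamino on the aromatic ring. A longer chain or a simple methyl group on the saturated ring carbon is also untested among the compounds shown.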